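Replacing a methylphenyl by a dichlorophenyl: what to expect

A few compounds are considered here, and "the series" means these few. Any claim that something is new, unique, unknown or untested is made for them only; others in the source may bear on it.

Measured compounds in an ADME assay on HUVEC cells (Homo sapiens) for antiproliferative activity, read by MTT assay, with a stated time of 48 h; on this read-out lower numbers stand for stronger inhibition and higher numbers for weaker inhibition:
compound 1 `N#CC1=C(N)Oc2c(c3nc4ccccc4nc3c3ccccc23)C12C(=O)N(Cc1cnnn1-c1cccc(Br)c1)c1ccccc12` gives a limit of > 50000 nM.
compound 2 `N#CC1=C(N)Oc2c(c3nc4ccccc4nc3c3ccccc23)C12C(=O)N(Cc1cnnn1-c1cccc(S(N)(=O)=O)c1)c1ccccc12` gives 38600 nM.
compound 3 `Cc1cccc(-n2nncc2CN2C(=O)C3(C(C#N)=C(N)Oc4c(N)cc5nc6ccccc6nc5c43)c3ccccc32)c1` gives a limit of > 50000 nM.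

Compound 3 stands at the limit of the assay, a value that is not a number; the same holds for compound 1, so that the limit of > 50000 nM in this assay, at which 2 of the 3 values shown sit, describes two of the three values shown. Among the measured compounds shown here, compound 2 is the only one with a numerical value, and it is weak.

Compound 4 `N#CC1=C(N)Oc2c(N)cc3nc4ccccc4nc3c2C12C(=O)N(Cc1cnnn1-c1cc(Cl)ccc1Cl)c1ccccc12` differs from compound 3 by 2,5-dichlorophenyl in place of 3-methylphenyl on an aromatic nitrogen. For the measured compounds named here, the only measured step, an at least 1.2-fold lower number from compound 1 to compound 2 (0.11 log units; that floor lies within the scatter), concerns a different position and a different pair of groups, and its size lies within the scatter, so it gives no direct guidance for the change from compound 3 to compound 4. Going by the values given here, with compound 3 at a limit and no comparable step available, there is nothing in the data pointing toward a gain in potency, and the expected step of a number no higher from compound 3 to compound 4 (the limit leaves the size open) is none beyond the scatter. Compound 4 is therefore estimated at 50000 nM in this assay, with a range from 15000 nM to 150000 nM, and it is quite likely that the assay again returns only a limit.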

Compound 4, half-maximal inhibitory concentration: > 50000 nM
Compound 4 ended at the assay's limit; the forecaster's own chance of this, stated with the estimate: 65%; the middle value lies on the limit itself.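

Among the compounds shown here, compound 3 and compound 4 each return only a limit in this assay, so the exchange of 3-methylphenyl for 2,5-dichlorophenyl yields no step that can be read: the limit of > 50000 nM in this assay, at which 3 of the 4 values shown sit. The compounds shown leave open how these two groups compare on this read-out, and at what concentration, if any, compound 3 or compound 4 would reach half-maximal inhibition.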